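The source may hold more compounds than are shown below. What is called first, only, known or untested is meant among the compounds shown, and "the series" means these compounds.

Measured compounds:
Compound 1 `O=C1O/C(=C\Cn2cc(Cc3ccccc3)nn2)C(OCc2ccccc2)=C1OCc1ccccc1`: 40000 nM in a functional assay on MCF7 cells (Homo sapiens) for antiproliferative activity, read by MTT assay, with a stated time of 24 h; on this read-out higher numbers stand for weaker inhibition and lower numbers for stronger inhibition
Compound 2 `CC(C)(C)c1ccc(-c2cn(C/C=C3\OC(=O)C(OCc4ccccc4)=C3OCc3ccccc3)nn2)cc1`: > 100000 nM in this assay, a limit
Compound 3 `O=C1O/C(=C\Cn2cc(-c3ccccn3)nn2)C(OCc2ccccc2)=C1OCc1ccccc1`: > 100000 nM in this assay, a limit

Compound 3 thus sits at the limit of > 100000 nM in this assay, at which 2 of the 3 values shown sit, and has no number of its own. Compound 4 `O=C1O/C(=C\Cn2cc(-c3ccccc3)nn2)C(OCc2ccccc2)=C1OCc1ccccc1` differs from it by phenyl in place of pyridin-2-yl on an aromatic carbon. The measured steps that touch this position are an at least 2.5-fold higher number from compound 1 to compound 2 (0.39 log units; beyond the scatter) and an at least 2.5-fold higher number from compound 1 to compound 3 (0.39 log units; beyond the scatter); the step that the two limits leave unreadable from compound 2 to compound 3 adds nothing readable. Both aryl groups attached directly to the triazole ring thus gave weaker inhibition than the benzyl of compound 1, and phenyl is a third such directly attached aryl. Compound 4 is therefore expected to give about 70000 nM in this assay, between 25000 nM and 150000 nM. The expected step of an at least 1.4-fold lower number from compound 3 to compound 4 (0.15 log units; that floor lies within the scatter) cannot be read exactly against a limit.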

Compound 4, half-maximal inhibitory concentration: > 100000 nM
Compound 4: a limit, no number; the forecaster's own chance of this, stated with the estimate: 45%; middle value at least 1.4-fold (0.15 log units) away from the limit.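

Phenyl, carrying neither the ring nitrogen of pyridin-2-yl nor a tert-butyl, also falls short of benzyl, with an at least 2.5-fold higher number from compound 1 to compound 4 (0.39 log units; beyond the scatter) in this assay. The steps from compound 2 and from compound 3 to compound 4 join two limits and cannot be read. Every directly attached aryl group shown now ends at the same place: the limit of > 100000 nM in this assay, at which 3 of the 4 values shown sit.

Still open, from the compounds shown here alone, is whether 2-phenylethyl, a longer chain than benzyl, would give stronger inhibition than compound 1. Also open, going by these compounds, is whether an amine or a carboxylic acid on the benzyl ring would change its value.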